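A few compounds are considered here, and "the series" means these few. Any claim that something is new, unique, unknown or untested is made for them only; others in the source may bear on it.

The study compares three measured compounds in an assay on HEK293 cells for positive allosteric modulation of metabotropic glutamate receptor 3 (Rattus norvegicus), read by thallium flux, with a stated time of 2.5 min; a lower number here means a smaller maximal response, a higher number a larger maximal response. For the measured compounds named here, compound 1 `Cc1c(OCCCCOc2ccccc2C(=O)O)ccc(C(=O)CC2CCCC2)c1C` gives 28% in this assay, and compound 2 `Cc1c(OCCCCOc2ccccc2C(=O)O)ccc(C(=O)CC2CCCC2)c1O` gives 32.9%; the one change between them, hydroxy in place of methyl on an aromatic carbon, brought a number 4.9 percentage points higher from compound 1 to compound 2 (within the scatter). Compound 3 `CCCC(=O)c1ccc(OCCCCOc2ccc(F)c(C(=O)O)c2)c(C)c1O` gives 56.9% in this assay. Among these three numbers compound 2 stands second highest: its nearest neighbour is compound 1, within the scatter, and its furthest is compound 3, whose number lies beyond the scatter above it.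

The account now turns to compound 4 `Cc1cc(C(=O)O)ccc1OCCCCOc1ccc(C(=O)CC2CCCC2)c(O)c1C`, which has not yet been measured in this assay. It differs from compound 2 in a single place: 4-carboxy-2-methylphenyl in place of 2-carboxyphenyl on an oxygen on a saturated carbon

Going by the values given here, none of the measured steps touches the 2-carboxyphenyl group, so no single step bears on this change directly. Compound 3 differs from compound 2 in several places at once, so its value shows only that a larger maximal response occurs within this set. Among the compounds with values here, with no directly relevant step, the expectation is a step of a number 3.1 percentage points higher from compound 2 to compound 4 (within the scatter), not clearly beyond the scatter. Compound 4 is therefore estimated at 36%, with a range from 15% to 60%.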

Compound 4, largest response reached (reported as percent of maximum), in percent of the reference or control that the assay uses: 28.4%
For compound 4 the middle estimate is 7.6 percentage points above the measured one; the range from low to high includes it.
By their numbers in this assay, from the lowest: compounds 1, 4 and 2 (each within the scatter of the next); then compound 3.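

In this assay the exchange of 2-carboxyphenyl for 4-carboxy-2-methylphenyl on an oxygen on a saturated carbon gave a number 4.5 percentage points lower from compound 2 to compound 4 (within the scatter), so compound 2 and compound 4 cannot be told apart in this read-out. For the compounds shown here, this is the first view of that place, and it shows that this aryl group can be exchanged, with its carboxy group carried at another ring position and a methyl added, without a clear shift in the maximal response. The step does not show why the two compounds read alike, and no measurement at hand bears on that question.

From the compounds shown here alone, the exchange alters two features at once, so the separate shares of the methyl and of the carboxy placement stay open, and a plain 4-carboxyphenyl group or a tetrazole in place of the carboxylic acid would be needed to separate them. Going by these compounds, it also remains open whether 4-carboxy-2-methylphenyl would behave the same way on the core of compound 3, which gives 56.9%, or with a longer chain linking the two rings.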